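A few compounds are considered here, and "the series" means these few. Any claim that something is new, unique, unknown or untested is made for them only; others in the source may bear on it.

Compound 1 `CCS(=O)(=O)N(Cc1cccnc1)c1ccc(C(=O)c2ccccc2)cc1`: 4200 nM
Compound 2 `CCS(=O)(=O)N(Cc1cccnc1)c1cccc(C(=O)c2ccccc2)c1`: 1100 nM
Compound 3 `C=C(c1ccccc1)c1ccc(N(Cc2cccnc2)S(=O)(=O)CC)cc1`: 780 nM

Of the compounds shown here, three have been measured in an assay on isolated protein with metabotropic glutamate receptor 2 (Homo sapiens) as the target; a higher number here means that more compound is needed for the effect, a lower number that less compound is needed. Compound 1 gives 4200 nM and compound 2 gives 1100 nM; the two are built from the same atoms joined differently, and the difference between the two cores is not broken down here, so the values alone show that compound 2 gives the lower number. Compound 3 gives 780 nM, and this value and that of compound 2 lie within the scatter of each other. Compound 3 arises from compound 1 by 1-phenylethenyl in place of benzoyl on an aromatic carbon, and that step is a 5.4-fold lower number from compound 1 to compound 3 (0.73 log units; beyond the scatter).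

Compound 4 `C=C(c1ccccc1)c1cccc(N(Cc2cccnc2)S(=O)(=O)CC)c1` has not yet been measured in this assay. It arises from compound 2 by 1-phenylethenyl in place of benzoyl on an aromatic carbon. For the measured compounds named here, this is the same kind of change as the one from compound 1 to compound 3, but not the same: there the place is para to a large group, here it is meta to a large group. Going by the values given here, because the one measured example of this change gave a 5.4-fold lower number from compound 1 to compound 3 (0.73 log units; beyond the scatter), a step of roughly a 4.4-fold lower number from compound 2 to compound 4 (0.64 log units; beyond the scatter) is expected from compound 2 to compound 4, with some allowance for the different place. Compound 4 is therefore estimated at 250 nM, expected to fall between 80 nM and 700 nM.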

Compound 4, half-maximal effective concentration: 200 nM
Compound 4: middle estimate off by 1.3-fold (0.10 log units), on the high side; the range from low to high includes it.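

In this assay, putting 1-phenylethenyl in place of benzoyl on an aromatic carbon of the second core gives a 5.5-fold lower number from compound 2 to compound 4 (0.74 log units; beyond the scatter). The change therefore carries over between these two cores with its size essentially unaltered, and the two steps cannot be told apart: the same change on two cores in this assay, a 5.4-fold lower number (0.73 log units; beyond the scatter) from compound 1 to compound 3 and a 5.5-fold lower number (0.74 log units; beyond the scatter) from compound 2 to compound 4, 1.0-fold (0.01 log units) apart, within the scatter of two such steps This shows that the step held on both cores, with the group placed differently in each, but two examples do not show that it would hold on any other core in the series, and they do not explain why the number falls.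

The compounds shown leave open how other groups would behave in this place, such as a saturated 1-phenylethyl group or an amine linking the phenyl ring to the core. They also leave open whether a longer chain in place of the ethyl on the sulfonyl group would change the size of this step.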